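Swapping Cyano for Carboxy on the Shared Core

This account rests on a few compounds, and the source may have more. Where it says the series, first, only, none or still open, it means among the compounds named here.

Small changes to a molecule are often tested one at a time to see which of them alter its effect on cells. In a functional assay on A549 cells (Homo sapiens) for cytotoxicity, read by colorimetric assay and MTT assay (a higher number here means a weaker inhibitor, a lower number a stronger inhibitor), compound 1 `CCN(CC)C(=O)Cn1c(=O)c(-c2ccc(OC)cc2)cc2c(OC)cc(OC)cc21` gives 10000 nM. In the same test compound 2 `COc1ccc(-c2cc3c(OC)cc(OC)cc3n(CC#N)c2=O)cc1` gives 10000 nM, which places it level with compound 1, its nearest neighbour in the data.

The next candidate is compound 3 `COc1ccc(-c2cc3c(OC)cc(OC)cc3n(CC(=O)O)c2=O)cc1`, which keeps the shared core and changes one group: carboxy in place of cyano on a saturated chain carbon bound to an aromatic nitrogen. In short, carboxy stands in place of cyano on a saturated chain carbon bound to an aromatic nitrogen.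

Among the compounds with values here, only one measured step bears on this position. Replacing diethylcarbamoyl with cyano there gave no change at the digits printed from compound 1 to compound 2 (within the scatter). Within the data shown here, that single result suggests this assay may respond little to changes at this carbon, but no compound carrying carboxy has been measured, so the evidence is indirect.

The expected outcome is no change at the digits printed from compound 2 to compound 3 (within the scatter), with no shift in either direction beyond the scatter. The estimate for compound 3 is 10000 nM, with an expected range from 5000 nM to 20000 nM.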

Compound 3, half-maximal inhibitory concentration: 10000 nM
Compound 3: the middle estimate sits on the measured number at the digits printed; measured number inside the range.
By their numbers in this assay, from the lowest: compounds 1, 2 and 3 (each within the scatter of the next).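

At the saturated chain carbon bound to an aromatic nitrogen, carboxy in place of cyano gave no change at the digits printed from compound 2 to compound 3 (within the scatter) in this assay and so added a third group to the comparison at this place. Read against the first compound of the set, hydroxy in place of diethylamino on a carbonyl carbon gave no change at the digits printed from compound 1 to compound 3 (within the scatter) and so shows that the amide and the carboxylic acid also read alike, which means that diethylcarbamoyl, cyano and carboxy at this carbon now all sit within the scatter of one another, a wider result than the single earlier step could give. Nothing measured here offers a reason for this flat reading.

On these data alone, whether an amine, a methyl ester or a longer chain at this carbon would separate from these three compounds stays open. Also open, as far as these compounds go, is whether replacing one of the methoxy groups on the shared core with, for example, a hydroxy group or a chlorine atom would move the number in this assay at all.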